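The source may hold more compounds than are shown below. What is called first, only, known or untested is meant among the compounds shown, and "the series" means these compounds.

The measured compounds:

Compound 1, `O=C(CSc1nc(Nc2ccccc2)c2ccccc2n1)Nc1ccccc1F`. In a functional assay on MDA-MB-231 cells (Homo sapiens) for inhibition, read by MTT assay, with a stated time of 72 h (on this read-out lower numbers stand for stronger inhibition and higher numbers for weaker inhibition), compound 1 gives > 50000 nM, which is a limit of the assay rather than a number.
Compound 2, `O=C(CSc1nc(Nc2ccccc2)c2ccccc2n1)Nc1cccc(Br)c1`. Compound 2 gives 17500 nM.
Compound 3, `C=CC(=O)Nc1cccc(NC(=O)CSc2nc(Nc3ccccc3)c3ccccc3n2)c1`. Compound 3 gives 10200 nM.

Compound 1 therefore sits at the limit of > 50000 nM in this assay, at which 1 of the 3 values shown sits, so its true value is not known; all that the numbers show is that it inhibits more weakly than compound 2 and compound 3, both of which gave steps beyond the scatter.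

The step to compound 4, `CCc1ccc(NC(=O)CSc2nc(Nc3ccccc3)c3ccccc3n2)cc1`, is this change: 4-ethylphenyl in place of 2-fluorophenyl on an amide-type nitrogen. For the measured compounds named here, two measured steps bear on it, since both also start from compound 1 and exchange the 2-fluorophenyl on the amide-type nitrogen: an at least 2.8-fold lower number from compound 1 to compound 2 (0.45 log units; beyond the scatter) and an at least 4.9-fold lower number from compound 1 to compound 3 (0.69 log units; beyond the scatter). In each case the replacement lowered the number beyond the scatter, although the exact size of either step is not known. The step of a 1.7-fold lower number from compound 2 to compound 3 (0.23 log units; within the scatter) shows that the two replacing groups gave much the same result as each other.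

On that basis compound 4 is expected to give 20000 nM, with a range from 8000 nM to 50000 nM. Going by the values given here, this estimate corresponds to an expected step of an at least 2.5-fold lower number from compound 1 to compound 4 (0.39 log units; beyond the scatter), a modest lowering of the number, with the caution that only two steps support it.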

Compound 4, half-maximal inhibitory concentration: 33900 nM
Beside the measured number, compound 4's estimate is 1.7-fold (0.23 log units) below it, within the range that was stated.
By their numbers in this assay, from the lowest: compounds 3, 2 and 4 (each within the scatter of the next, the first and the last beyond it). At a limit, above all of these: compound 1.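

The earlier replacements on this amide-type nitrogen all lowered the number beyond the scatter, but 4-ethylphenyl in place of 2-fluorophenyl gives an at least 1.4-fold lower number from compound 1 to compound 4 (0.16 log units; that floor lies within the scatter), so in this assay it cannot be said to improve on compound 1. Going by these compounds, compound 1 stands at a limit and not at a number, so the true size of this step stays unknown: the limit of > 50000 nM in this assay, at which 1 of the 4 values shown sits. The new compound also gives the first gap beyond the scatter between groups on this nitrogen with real numbers on both sides: 4-ethylphenyl inhibits more weakly than 3-((vinylcarbonyl)amino)phenyl, with a 3.3-fold higher number from compound 3 to compound 4 (0.52 log units; beyond the scatter), while it cannot be told apart from 3-bromophenyl, with a 1.9-fold higher number from compound 2 to compound 4 (0.29 log units; within the scatter).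

All four compounds carry a substituted phenyl on this nitrogen, and no substituent appears in two different places, so the effect of the group and the effect of its place on the ring cannot be separated. On these data alone, what an unsubstituted phenyl, a 3-ethylphenyl or a cyclohexyl would give on this nitrogen stays open.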